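Working notes on the aryl-substituent step toward compound 4

The source may report more compounds than this note shows. Statements on the series, on what has been measured and on what is new or still open speak of the compounds shown alone.

Measured so far:
compound 1, `COc1ccc2cc(/C=C3\CCCN=C3c3cccnc3)ccc2c1`: 600 nM
compound 2, `C(=C1\CCCN=C1c1cccnc1)\c1ccc(-n2ccnn2)cc1`: 520 nM
compound 3, `CSc1ccc(/C=C2\CCCN=C2c2cccnc2)cc1`: 900 nM

The three measured compounds share one core and differ only in the substituent on the aromatic ring attached to the exocyclic double bond. In an assay on membranes from brain for displacement of a labelled ligand from Neuronal acetylcholine receptor; alpha4/beta2 (Rattus norvegicus), with a stated time of 3 h (on this read-out lower numbers stand for stronger inhibition and higher numbers for weaker inhibition), compound 3 gives 900 nM, the highest of the three numbers; compound 1 gives 600 nM and compound 2 gives 520 nM, and both lie within the scatter of compound 3, so no order among the three can be drawn. Going by the values given here, the single step that swaps one substituent on that aromatic carbon for another, a 1.7-fold higher number from compound 2 to compound 3 (0.24 log units; within the scatter), stays within the scatter.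

Compound 4, `CC(C)(C)C(=O)Oc1ccc(/C=C2\CCCN=C2c2cccnc2)cc1`, is not yet measured. Its change from compound 3: ((tert-butyl)carbonyl)oxy in place of methylsulfanyl on an aromatic carbon. Among the compounds with values here, the only measured step that bears on this change is a 1.7-fold higher number from compound 2 to compound 3 (0.24 log units; within the scatter), and it shows no movement beyond the scatter. Within the data shown here, no measured compound carries ((tert-butyl)carbonyl)oxy, so the entering group itself is uncharted; the range is therefore set wide. A step within the scatter is expected, a 1.1-fold higher number from compound 3 to compound 4 (0.05 log units; within the scatter). Compound 4 is expected to give 1000 nM, within 400 nM to 2500 nM.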

Compound 4, inhibition constant: 830 nM
Compound 4: the middle estimate sits 1.2-fold (0.08 log units) above what was measured; the measured number falls inside the stated range.
By their numbers in this assay, from the lowest: compounds 2, 1, 4 and 3 (each within the scatter of the next).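

In this assay, ((tert-butyl)carbonyl)oxy in place of methylsulfanyl on an aromatic carbon, para to a large group, gives a 1.1-fold lower number from compound 3 to compound 4 (0.04 log units; within the scatter) and the same group in place of 1H-1,2,3-triazol-1-yl gives a 1.6-fold higher number from compound 2 to compound 4 (0.20 log units; within the scatter) and both steps stay within the scatter. Going by these compounds alone, until now the only step read at this position was between methylsulfanyl and 1H-1,2,3-triazol-1-yl, whereas this change brings in a group of 7 heavy atoms with a carbonyl for one of 2 heavy atoms, and the read-out still shows no movement beyond the scatter, so at this position the group's size in heavy atoms and the added double bond go with no readable change across these compounds. The data shown offer no explanation for this flat result.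

As far as these compounds go, whether an amine, a carboxylic acid or a longer alkyl chain on this aromatic carbon would move the number beyond the scatter remains open. Also open is how a hydroxyl group or a plain hydrogen at this position would compare with the groups shown.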